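The source may hold more compounds than are shown below. What is called first, only, known or untested is meant among the compounds shown, and "the series" means these compounds.

Three compounds share a common core and differ only in the group attached to one carbonyl carbon. Compound 1 `COC(=O)c1cncc(NS(=O)(=O)c2cc(Cl)ccc2OC)c1` carries a methoxy there. In an assay on isolated protein for inhibition of alkaline phosphatase, tissue-nonspecific isozyme (Homo sapiens) (on this read-out lower numbers stand for stronger inhibition and higher numbers for weaker inhibition), compound 1 gives > 20000 nM, which is a limit of the assay rather than a number (the limit of > 20000 nM in this assay, at which 1 of the 3 values shown sits). Compound 2 `COc1ccc(Cl)cc1S(=O)(=O)Nc1cncc(-c2ccc(Cl)cc2)c1` has an aryl group in place of that carbonyl, and in this assay compound 2 gives "not determined" (no result reported). Among the compounds with values here, compound 3 `COc1ccc(Cl)cc1S(=O)(=O)Nc1cncc(C(N)=O)c1` carries an amino on the carbonyl carbon, and in this assay compound 3 gives 105 nM, the only plain number among the three. Within the data shown here, the one measured step, an at least 190-fold lower number from compound 1 to compound 3 (2.27 log units; beyond the scatter), shows that the group on this carbonyl carbon can move the result a great deal.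

Compound 4 `COc1ccc(Cl)cc1S(=O)(=O)Nc1cncc(C(=O)O)c1` is the next member: hydroxy in place of amino on a carbonyl carbon. Hydroxy, like amino, keeps a hydrogen-bond donor at that place, whereas methoxy in compound 1 had none; whether a hydroxy behaves more like the amino of compound 3 or like the methoxy of compound 1 is not shown by these compounds. A loss of potency is therefore expected, but smaller than the drop to the limit seen for compound 1, with the step from compound 3 to compound 4 estimated at a 19-fold higher number from compound 3 to compound 4 (1.28 log units; beyond the scatter). Compound 4 is expected to give about 2000 nM, within a range from 300 nM to 20000 nM.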

Compound 4, half-maximal inhibitory concentration: > 20000 nM
Compound 4: no number, only a limit; the forecaster's own chance of this, stated with the estimate: 25%; middle value at least 10-fold (1.00 log units) from the limit.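

Replacing amino with hydroxy on a carbonyl carbon, the change from carbamoyl to carboxy, gives an at least 190-fold higher number from compound 3 to compound 4 (2.27 log units; beyond the scatter), so exchanging a single heavy atom at this position is enough to turn a plain number into a limit of the assay in this assay. The two groups each count as one hydrogen-bond donor, which means a donor on this carbonyl carbon is not sufficient for a measurable result: compound 4 has one and still reaches only a limit of the assay. Compound 4 now joins compound 1 at that limit, so the step between them cannot be read and hydroxy and methoxy cannot be ranked against each other: the limit of > 20000 nM in this assay, at which 2 of the 4 values shown sit.

Amino remains the only group shown here that gives a plain number, and how a methylamino or a dimethylamino group on the same carbonyl carbon would read stays open, so it is unknown whether the result depends on both amide hydrogens or on the nitrogen alone. How far compound 4 lies beyond its limit also stays open, as does any explanation for the size of this step.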